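Pyrazoline series: methoxy for trifluoromethyl on the second pair

The source may hold more compounds than are shown below. What is called first, only, known or untested is meant among the compounds shown, and "the series" means these compounds.

Compound 1 `FC(F)(F)c1ccc(C2CC(c3ccccc3)=NN2c2ccc(-c3ccccc3)nn2)cc1` is the reference of the set. In a functional assay on HepG2 cells (Homo sapiens) for antiproliferative activity, read by MTT assay, with a stated time of 24 h (on this read-out higher numbers stand for weaker inhibition and lower numbers for stronger inhibition), compound 1 gives 10000 nM. Compound 2 `COc1ccc(C2CC(c3ccccc3)=NN2c2ccc(-c3ccccc3)nn2)cc1` carries methoxy in place of trifluoromethyl on an aromatic carbon, and that move gives an at least 10-fold higher number from compound 1 to compound 2 (1.00 log units; beyond the scatter). For compound 2 the reading in this assay is a limit of the assay, > 100000 nM. Compound 3 `COc1ccc(C2=NN(c3ccc(-c4ccccc4)nn3)C(c3ccc(C(F)(F)F)cc3)C2)cc1` differs from compound 1 in its core by methoxy in place of hydrogen on an aromatic carbon, a move that gives an at least 10-fold higher number from compound 1 to compound 3 (1.00 log units; beyond the scatter). For compound 3 too this assay returns only a limit, > 100000 nM. Two of the three readings in hand therefore sit at the limit of > 100000 nM in this assay, at which 2 of the 3 values shown sit, which is all that can be said of either.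

Compound 4 `COc1ccc(C2=NN(c3ccc(-c4ccccc4)nn3)C(c3ccc(OC)cc3)C2)cc1` is not yet measured. It stands to compound 3 as compound 2 stands to compound 1, by methoxy in place of trifluoromethyl on an aromatic carbon: the same change, at a place described in the same words. The expected step is a step that the limit leaves unreadable from compound 3 to compound 4, resting on an at least 10-fold higher number from compound 1 to compound 2 (1.00 log units; beyond the scatter) and on the fact that compound 3 already sits at the limit. Compound 4 is therefore expected to give 200000 nM in this assay, most probably again reported as a limit rather than a number, with an expected range from 60000 nM to 1000000 nM.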

Compound 4, half-maximal inhibitory concentration: > 100000 nM
Compound 4: no number, only a limit (the forecaster's own chance of this, stated with the estimate: 85%); the middle value lies beyond the limit too.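

In this assay compound 4 gives > 100000 nM, a limit of the assay and not a number, so the steps to it from compound 2 and compound 3 cannot be read. The compounds shown leave open how far compound 2, compound 3 and compound 4 differ from one another, and whether methoxy in place of trifluoromethyl changes anything on the compound 3 side.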